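Ring swap at the amine nitrogen: pyridin-2-yl for difluorophenyl

The source may report more compounds than this note shows. Statements on the series, on what has been measured and on what is new or still open speak of the compounds shown alone.

The series shares the core of compound 1 `CCCCNc1nc(N)nc2c1CN(C(=O)c1ccccc1)CC2` and varies only the group on the amine nitrogen in the ring. In an assay on HEK293 cells for agonist activity at Toll-like receptor 8 (Homo sapiens), read by a luciferase reporter, with a stated time of 6 h (on this read-out lower numbers stand for an effect already at smaller amounts and higher numbers for an effect only at larger amounts of compound), compound 1 gives 1.4 uM. Compound 2 `CCCCNc1nc(N)nc2c1CN(S(C)(=O)=O)CC2` gives 9.9 uM in this assay, and the step of a 7.1-fold higher number from compound 1 to compound 2 (0.85 log units; beyond the scatter) shows that this position moves the number. Compound 3 `CCCCNc1nc(N)nc2c1CN(Cc1cc(F)cc(F)c1)CC2` gives 0.23 uM in this assay, the lowest of the three numbers, with compound 1 nearer and compound 2 furthest, both gaps beyond the scatter. Compound 4 `CCCCNc1nc(N)nc2c1CN(Cc1ccccn1)CC2` differs from compound 3 by pyridin-2-yl in place of 3,5-difluorophenyl on a saturated chain carbon bound to an amine nitrogen in a ring. For the measured compounds named here, no measured step alters the ring on the saturated chain carbon bound to the amine nitrogen in the ring, so the single step on record bears only indirectly. A modest rise is expected, a 2.6-fold higher number from compound 3 to compound 4 (0.42 log units; beyond the scatter). Compound 4 is therefore estimated at 0.6 uM in this assay, within 0.2 uM to 2 uM.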

Compound 4, minimum effective concentration: 0.07 uM
Compound 4: the middle estimate sits 8.6-fold (0.93 log units) above what was measured; the measured number lies below the stated range.
By their numbers in this assay, from the lowest: compound 4; then compound 3; then compound 1; then compound 2.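

In this assay the ring on the saturated chain carbon now proves to matter by itself, with a 3.3-fold lower number from compound 3 to compound 4 (0.52 log units; beyond the scatter) when pyridin-2-yl replaces 3,5-difluorophenyl. Against the other groups on the amine nitrogen in the ring the span at this position widens, with a 20-fold lower number from compound 1 to compound 4 (1.30 log units; beyond the scatter) for the change from benzoyl and a 140-fold lower number from compound 2 to compound 4 (2.15 log units; beyond the scatter) for the change from methylsulfonyl. Still open, as far as these compounds go, is whether plain phenyl or pyridin-3-yl on the same carbon would keep the lower number. Nothing on record accounts for these steps.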